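From Vinyl to Ethynyl on the Amine Arm

This account rests on a few compounds, and the source may have more. Where it says the series, first, only, none or still open, it means among the compounds named here.

Three compounds share one core and differ only in the group on a saturated chain carbon bound to an amine nitrogen. Compound 1 `Nc1ncnc2c1ncn2[C@@H]1O[C@H](CN(CC[C@H](N)C(=O)O)CC2CC2)[C@@H](O)[C@H]1O` carries a cyclopropyl there, and in an assay for inhibition of tRNA (cytosine(38)-C(5))-methyltransferase (Homo sapiens), with a stated time of 5 min, tested at 100 uM (a higher number here means more inhibition at the concentration tested (going by the name of the read-out), a lower number less inhibition), compound 1 gives 27.5%. Compound 2 `Nc1ncnc2c1ncn2[C@@H]1O[C@H](CN(CC[C@H](N)C(=O)O)CC2CCCC2)[C@@H](O)[C@H]1O` carries a cyclopentyl, and in this assay compound 2 gives 24.5%. Compound 3 `C=CCN(CC[C@H](N)C(=O)O)C[C@H]1O[C@@H](n2cnc3c(N)ncnc32)[C@H](O)[C@@H]1O` carries a vinyl, and in this assay compound 3 gives 53.9%, the highest of the three numbers. The step of a number 26.4 percentage points higher from compound 1 to compound 3 (beyond the scatter) and the step of a number 29.4 percentage points higher from compound 2 to compound 3 (beyond the scatter) both lie beyond the scatter, whereas a number 3 percentage points lower from compound 1 to compound 2 (within the scatter) lies within it.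

Compound 4 `C#CCN(CC[C@H](N)C(=O)O)C[C@H]1O[C@@H](n2cnc3c(N)ncnc32)[C@H](O)[C@@H]1O` follows with one change: ethynyl in place of vinyl on a saturated chain carbon bound to an amine nitrogen. The two measured steps toward compound 3 each exchange a ring for an open two-carbon group; neither swaps a double bond for a triple bond, so they bear only loosely on this change and give no direction for it. The expected step is therefore a number 3.9 percentage points lower from compound 3 to compound 4 (within the scatter), small and within the scatter. Compound 4 is expected to give 50% in this assay, with a range from 35% to 65%.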

Compound 4, a percentage reported as inhibition, at one concentration (the size of the read-out at that concentration, not a potency): 72.2%
For compound 4 the middle estimate is 22.2 percentage points below the measured one; measured number above the stated range.
By their numbers in this assay, from the lowest: compounds 2 and 1 (each within the scatter of the next); then compound 3; then compound 4.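

In this assay the bond type in the group on a saturated chain carbon bound to an amine nitrogen matters: ethynyl in place of vinyl gives a number 18.3 percentage points higher from compound 3 to compound 4 (beyond the scatter) although both groups have two carbons, no ring and no hydrogen-bond donors or acceptors. The earlier compounds shown here separated only the rings from vinyl, and ethynyl stretches that separation to a number 44.7 percentage points higher from compound 1 to compound 4 (beyond the scatter) and a number 47.7 percentage points higher from compound 2 to compound 4 (beyond the scatter), so open two-carbon groups are no longer a single level here. Nothing measured here accounts for the higher number with the triple bond.

Still open, from the compounds shown here alone, is whether a saturated ethyl at this place would fall with the ring compounds or nearer the vinyl compound. A nitrile or a longer chain ending in a triple bond could also show whether the rise continues.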